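The source may report more compounds than this note shows. Statements on the series, on what has been measured and on what is new or still open speak of the compounds shown alone.

Measured so far in this series:
compound 1 `O=C1N=C(N2N=C(c3ccccc3)CC2c2ccccc2O)S/C1=C1/C(=O)Nc2ccccc21`: 2070 nM
compound 2 `O=C1N=C(N2N=C(c3ccccc3)CC2c2ccccc2O)S/C1=C1/C(=O)Nc2ccc(Br)cc21`: 230 nM
compound 3 `COc1ccc(C2=NN(C3=NC(=O)/C(=C4\C(=O)Nc5ccccc54)S3)C(c3ccc(OC)cc3)C2)cc1`: 85200 nM

All three were run in a functional assay on cells (Cancer cell lines, Homo sapiens) for cytotoxicity, read by sulforhodamine B assay, with a stated time of 48 h; on this read-out higher numbers stand for weaker inhibition of growth and lower numbers for stronger inhibition of growth. The change within the first pair is bromo in place of hydrogen on an aromatic carbon, and it gave a 9.0-fold lower number from compound 1 to compound 2 (0.95 log units; beyond the scatter). Compound 3 sits on a different core; the difference between the two cores is not broken down here, and compound 3 gives the highest number of the three.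

Compound 4 `COc1ccc(C2=NN(C3=NC(=O)/C(=C4\C(=O)Nc5ccc(Br)cc54)S3)C(c3ccc(OC)cc3)C2)cc1` has not yet been measured in this assay. It differs from compound 3 by bromo in place of hydrogen on an aromatic carbon, the same change as that made from compound 1 to compound 2. For the measured compounds named here, the step from compound 3 to compound 4 is expected to be a 5.0-fold lower number from compound 3 to compound 4 (0.70 log units; beyond the scatter), somewhat smaller than the earlier one, because the same change on the other core gave a 9.0-fold lower number from compound 1 to compound 2 (0.95 log units; beyond the scatter) and only that single pair supports it. Compound 4 is therefore estimated at 17000 nM, with a likely range from 5000 nM to 60000 nM.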

Compound 4, concentration for 50% growth inhibition: 200 nM
Beside the measured number, compound 4's estimate is 85-fold (1.93 log units) above it, and the stated range ends above it.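

In this assay, bromo in place of hydrogen on an aromatic carbon lowers the number on the second core as well, giving a 430-fold lower number from compound 3 to compound 4 (2.63 log units; beyond the scatter), so the direction of the change holds on both cores shown. The size of the step does not carry over from one core to the other: the same change on two cores in this assay, a 9.0-fold lower number (0.95 log units; beyond the scatter) from compound 1 to compound 2 and a 430-fold lower number (2.63 log units; beyond the scatter) from compound 3 to compound 4, 47-fold (1.68 log units) apart, beyond the scatter of two such steps

These two pairs show one change at one place and do not show which difference between the cores goes with the gap in size. Open, on these data alone, is whether chloro or methyl on the same aromatic carbon would follow bromo on both cores. Also open, as far as these compounds go, is whether an amine there would lower the number at all.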